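The compounds below may be only part of what the source reports. "The series", "measured", "known", "first", "only" and "open" are said of these compounds alone.

Of the compounds shown here, three have been measured in a functional assay on PC-3 cells (Homo sapiens) for antiproliferative activity, read by MTT assay, tested at 5 uM; on this read-out higher numbers stand for a stronger effect at the one concentration tested and lower numbers for a weaker effect. Compound 1 `COc1ccc(/C=N/NC(=O)c2cc(OC)c(OC)c(OC)c2)c(OC)c1` gives 22.2%. Compound 2 `COc1cc(C2=NN(C(C)=O)C(c3cc(Cl)cc(Cl)c3)O2)cc(OC)c1OC` gives 93.9%, the highest of the three numbers, and compound 3 `COc1cc(C2=NN(C(C)=O)C(c3cc(OC)c(OC)c(OC)c3)O2)cc(OC)c1OC` gives 0.1%. Compound 2 thus stands well clear of both others: the gap to compound 1 and the still wider gap to compound 3 both lie beyond the usual scatter of this assay.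

Compound 4 `COc1cc(C2=NN(C(C)=O)C(c3ccc(F)cc3)O2)cc(OC)c1OC` has not yet been measured. It differs from compound 2 in one place: 4-fluorophenyl in place of 3,5-dichlorophenyl on a saturated ring carbon. The group that enters is a halogenated phenyl, as is the group that leaves, but it carries one halogen rather than two. Within the data shown here, no measured pair tells how such a change shifts this assay, so the expectation rests on the three values alone.

The step from compound 2 to compound 4 is expected to be a fall of moderate size, beyond the scatter, namely a number 33.9 percentage points lower from compound 2 to compound 4 (beyond the scatter). Compound 4 is therefore estimated at 60%, with a range from 20% to 92%.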

Compound 4, a percentage reported as inhibition, at one concentration (the size of the read-out at that concentration, not a potency): 0.1%
For compound 4 the middle estimate is 59.9 percentage points above the measured one; the whole stated range lies above it.
By their numbers in this assay, from the lowest: compounds 3 and 4 (each within the scatter of the next); then compound 1; then compound 2.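

In this assay the exchange of 3,5-dichlorophenyl for 4-fluorophenyl on this saturated ring carbon gives a number 93.8 percentage points lower from compound 2 to compound 4 (beyond the scatter) and so leaves almost no effect at the one concentration tested. A halogenated phenyl at this position is therefore not enough in itself: compound 4 at 0.1% lies within the scatter of compound 3 at 0.1% even though compound 3 carries no halogen. Nothing available explains this fall.

The single step changes the kind, the number and the place of the halogen together, so the compounds shown do not separate these; 3,5-difluorophenyl or 4-chlorophenyl at this carbon would begin to do so. They also leave open whether a phenyl bearing an amine or a carboxylic acid is tolerated here.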